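Swapping Cyclopropyl for Butyl on the Amide Carbonyl

The source may report more compounds than this note shows. Statements on the series, on what has been measured and on what is new or still open speak of the compounds shown alone.

Compound 1, `COc1ccc(CN(C(=O)C2CC2)c2cc(OC)c(OC)c(OC)c2)cc1O`: 59 nM
Compound 2, `COc1ccc(CNc2cc(OC)c(OC)c(OC)c2)cc1C`: 56800 nM
Compound 3, `COc1ccc(CNc2cc(OC)c(OC)c(OC)c2)cc1Br`: 29400 nM

In a functional assay on MGC-803 cells (Homo sapiens) for inhibition, read by MTT assay, with a stated time of 48 h (a lower number here means a stronger inhibitor, a higher number a weaker inhibitor), compound 1 gives 59 nM, the lowest of the three numbers. Compound 3 gives 29400 nM and compound 2 gives 56800 nM, both far higher than compound 1 and beyond the scatter. Among the measured compounds shown here, the one step between measured compounds, a 1.9-fold lower number from compound 2 to compound 3 (0.29 log units; within the scatter), concerns bromo in place of methyl on an aromatic carbon and stays within the scatter; it says nothing about the carbonyl side of the molecule.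

Compound 4, `CCCCC(=O)N(Cc1ccc(OC)c(O)c1)c1cc(OC)c(OC)c(OC)c1`, differs from compound 1 by butyl in place of cyclopropyl on a carbonyl carbon. No measured pair shares this change, so nothing shown here points in either direction for this assay. The expected step is therefore small, a 1.7-fold higher number from compound 1 to compound 4 (0.23 log units; within the scatter), with a wide allowance for the lack of a comparable step. Compound 4 is expected to give about 100 nM in this assay, estimated to fall between 30 nM and 400 nM.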

Compound 4, half-maximal inhibitory concentration: 66 nM
The estimate for compound 4 lay 1.5-fold (0.18 log units) above the measured number, within the range that was stated.
By their numbers in this assay, from the lowest: compounds 1 and 4 (each within the scatter of the next); then compounds 3 and 2 (each within the scatter of the next).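

In this assay butyl in place of cyclopropyl on a carbonyl carbon gives a 1.1-fold higher number from compound 1 to compound 4 (0.05 log units; within the scatter) and so, for this pair, an open chain serves as well as the three-membered ring. Among the compounds shown here, this is the first measured change on the carbonyl side of the molecule, which the earlier step between two compounds without that carbonyl could not address. Nothing measured here explains why the two groups match.

Going by these compounds, whether a shorter chain such as ethyl, a branched one such as tert-butyl, or a chain ending in an amine or a carboxylic acid would match them stays open. Compound 2 and compound 3 differ from compound 1 in more than one place, so their much higher numbers cannot be assigned to the carbonyl group alone.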